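The source may report more compounds than this note shows. Statements on the series, on what has been measured and on what is new or still open speak of the compounds shown alone.

Working notes on the series. All three compounds with a number share one core and differ only in the aryl group carried on it. Compound 1 `Cn1c(-c2ccc(-c3cncnc3)cc2)nnc1C1(c2ccc(Cl)cc2)CCC1` and compound 2 `Cn1c(-c2ccc(C(N)=O)cc2C(N)=O)nnc1C1(c2ccc(Cl)cc2)CCC1` both sit near the bottom of what has been seen so far: in a functional assay on the whole organism (strain ICR) for inhibition, with Mus musculus as the target, read by scintillation counting, with a stated time of 16 h, at a dose of 10 mg/kg by the oral route (a higher number here means more inhibition at the dose given (going by the name of the read-out), a lower number less inhibition), compound 1 gives -4% and compound 2 gives 0%, two numbers that lie within the scatter of each other, so nothing separates them. Compound 3 `Cn1c(-c2ccc(-c3cnccn3)cc2F)nnc1C1(c2ccc(Cl)cc2)CCC1` stands apart: in this assay compound 3 gives 81%, a number far beyond the scatter from compound 2. Compound 2 thus sits with compound 1 at the low end and well beneath compound 3.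

The next compound, compound 4 `Cn1c(-c2ccc(C(N)=O)cc2Cl)nnc1C1(c2ccc(Cl)cc2)CCC1`, has not yet been run. It differs from compound 2 in one place: chloro in place of carbamoyl on an aromatic carbon. Within the data shown here, no measured pair isolates this change, so its size can only be guessed from what compound 2 and compound 3 show. The step from compound 2 to compound 4 is expected to be modest and upward, a number 20 percentage points higher from compound 2 to compound 4 (beyond the scatter), with the possibility of no change beyond the scatter. Compound 4 is therefore estimated at 20% in this assay, within a range from -10% to 55%.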

Compound 4, a percentage reported as inhibition, in the whole organism at one dose (the size of the read-out at that dose, not a potency): 12%
The estimate for compound 4 lay 8 percentage points above the measured number; low and high end bracket the measured number.
By their numbers in this assay, from the lowest: compounds 1 and 2 (each within the scatter of the next); then compound 4; then compound 3.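

Among these compounds, compound 2 to compound 4 is the first pair to isolate chloro in place of carbamoyl on an aromatic carbon, ortho to a large group and meta to a carbamoyl group, and in this assay it gives a number 12 percentage points higher from compound 2 to compound 4 (beyond the scatter) in a step of modest size. At this place, then, the carbamoyl can be given up without loss of inhibition at the dose used, and the single heavy atom of chloro, carrying no hydrogen-bond donor or acceptor, gives a small gain over the larger carbamoyl. Nothing at hand accounts for the step, so it stands as an observation without a cause.

On these data alone, how other groups at this place would read in this assay remains open, for example a methyl, a methoxy or an amine, since a single swap says nothing about a trend across substituents. Also open, as far as these compounds go, is whether the step from chloro would hold with the carbamoyl that stays in compound 4 replaced by a carboxylic acid or a nitrile, as the change has been read against one background only.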